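Aryl ether swap on the dioxane series

The compounds below may be only part of what the source reports. "The series", "measured", "known", "first", "only" and "open" are said of these compounds alone.

Measured so far:
compound 1, `O=C(O)CC/C=C\CC1COC(c2cccc3ccccc23)OC1c1cccnc1`: 631 nM
compound 2, `Cc1ccc(C#N)c(OC(C)(C)C2OCC(C/C=C\CCC(=O)O)C(c3cccnc3)O2)c1`: 15.9 nM

In a functional assay for inhibition, with Homo sapiens as the target (a higher number here means weaker binding, a lower number tighter binding), compound 2 gives 15.9 nM, the lower of the two numbers measured. Compound 1 gives 631 nM in this assay, a gap from compound 2 that lies beyond the usual scatter. Going by the values given here, the two compounds differ in several places at once, so no single-change step is available from them.

Compound 3, `CC(C)(Oc1ccc(F)cc1[N+](=O)[O-])C1OCC(C/C=C\CCC(=O)O)C(c2cccnc2)O1`, is not yet measured. It differs from compound 2 by 4-fluoro-2-nitrophenyl in place of 2-cyano-5-methylphenyl on an oxygen on a saturated carbon. Among the compounds with values here, no measured pair isolates this kind of exchange, so the direction of the step rests on no measured precedent.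

Compound 3 is expected to stay close to compound 2, with a step of a 1.6-fold higher number from compound 2 to compound 3 (0.20 log units; within the scatter), within or only just beyond the scatter. The estimate for compound 3 in this assay is 25 nM, with a range from 8 nM to 80 nM.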

Compound 3, dissociation constant: 2.51 nM
Beside the measured number, compound 3's estimate is 10-fold (1.00 log units) above it, and the stated range ends above it.
By their numbers in this assay, from the lowest: compound 3; then compound 2; then compound 1.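

In this assay, the group on the oxygen on a saturated carbon emerges as a place where one exchange moves the number beyond the scatter, with 4-fluoro-2-nitrophenyl in place of 2-cyano-5-methylphenyl giving a 6.3-fold lower number from compound 2 to compound 3 (0.80 log units; beyond the scatter). Going by these compounds alone, this is the only single-change step, and it shows that the nitrile and the methyl can both be lost from this group with the number going down, the six-membered aromatic ring of carbon only staying in place. Nothing measured here accounts for the size of this step.

The fluorine and the nitro group enter together, so compound 3 does not show what each contributes, or whether a phenyl group carrying only one of them, or a chlorine or an amine instead, would hold the number. Also open, from the compounds shown here alone, is whether a saturated ring such as cyclohexyl on this oxygen would be tolerated.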